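The source may hold more compounds than are shown below. What is called first, only, known or untested is meant among the compounds shown, and "the series" means these compounds.

Of the compounds shown here, three sharing one core have been tested in a functional assay on cells (Cancer cell lines, Homo sapiens) for inhibition; on this read-out lower numbers stand for stronger inhibition of growth and higher numbers for weaker inhibition of growth. Compound 1 `COc1ccc(-c2nc3sc(Cc4ccccc4)nn3c2SC#N)cc1` gives 55000 nM in this assay, the highest of the three numbers. Compound 3 `O=Cc1c(-c2ccc([N+](=O)[O-])cc2)nc2sc(Cc3ccccc3)nn12` gives 26900 nM, a lower number than compound 1 by a margin beyond the usual scatter. Compound 2 `Clc1ccc(-c2cn3nc(Cc4ccccc4)sc3n2)cc1` gives 13800 nM, the lowest of the three and again beyond the scatter from compound 1. Compound 2 and compound 3 carry different groups at more than one place compared with compound 1, so no single structural change can be tied to these gaps.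

Compound 4 `N#CSc1c(-c2ccccc2)nc2sc(Cc3ccccc3)nn12` has not yet been measured in this assay. It differs from compound 1 in one place: hydrogen in place of methoxy on an aromatic carbon. Seen from one bond further out, the 4-methoxyphenyl becomes a plain phenyl.

Within the data shown here, no pair of measured compounds differing only at this place exists here, so the size of this step has to be estimated rather than read off. Compound 4 is expected to show a small step from compound 1, a 1.4-fold lower number from compound 1 to compound 4 (0.14 log units; within the scatter), within or close to the scatter. For compound 4 the estimated value in this assay is 40000 nM, with a range from 15000 nM to 110000 nM.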

Compound 4, concentration for total growth inhibition: 77600 nM
Beside the measured number, compound 4's estimate is 1.9-fold (0.29 log units) below it; the range from low to high includes it.
By their numbers in this assay, from the lowest: compounds 2 and 3 (each within the scatter of the next); then compounds 1 and 4 (each within the scatter of the next).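

In this assay, replacing the methoxy on the aromatic ring with hydrogen, which turns the 4-methoxyphenyl into a plain phenyl, gives a 1.4-fold higher number from compound 1 to compound 4 (0.15 log units; within the scatter). Among these compounds, this is the first single-place comparison, and it shows that the two compounds cannot be told apart on this read-out. Within this pair, the methoxy, with its two heavy atoms and one hydrogen-bond acceptor, can therefore be removed without a change that rises above the scatter. No available measurement explains this result.

On these data alone, one step at one position cannot show whether this place is insensitive to substitution in general, so it remains open whether an amine, a carboxylic acid or a longer chain such as butoxy on the same ring carbon would shift the number beyond the scatter. As far as these compounds go, it also remains open whether hydrogen in place of methoxy would give a similarly small step if the other groups on the shared core were different.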